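Replacing trifluoromethyl with tert-butoxy on compound 3

The source may hold more compounds than are shown below. What is called first, only, known or untested is meant among the compounds shown, and "the series" means these compounds.

Going by the values given here, in an ADME assay on S9 fraction from liver (Homo sapiens) for metabolic stability, with a stated time of 1 h (on this read-out higher numbers stand for a more stable compound and lower numbers for a less stable compound), compound 3 `N#Cc1cnc(NCc2cncnc2C(F)(F)F)cc1N[C@H]1CC[C@@H](O)CC1` gives 76%, the highest number so far, ahead of compound 1 `N#Cc1cnc(NCc2cnccc2C(F)(F)F)cc1N[C@H]1CC[C@@H](O)CC1` at 33% and compound 2 `CO[C@H]1CC[C@@H](Nc2cc(NCc3cnccc3C(F)(F)F)ncc2C#N)CC1` at 19%. Compound 4 `CC(C)(C)Oc1ncncc1CNc1cc(N[C@H]2CC[C@@H](O)CC2)c(C#N)cn1` differs from compound 3 by a single change: tert-butoxy in place of trifluoromethyl on an aromatic carbon. Among the compounds with values here, no measured step covers tert-butoxy in place of trifluoromethyl on an aromatic carbon. Within the data shown here, the one step available, a number 14 percentage points lower from compound 1 to compound 2 (beyond the scatter), concerns a different group, so it serves only as a rough guide to size. With compound 3 at 76%, the number has more room to fall than to rise. The expected change is a drop somewhat larger than that guide, a number 24 percentage points lower from compound 3 to compound 4 (beyond the scatter). Compound 4 is estimated at 52%, within a range of 27% to 76%.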

Compound 4, percent of the compound remaining: 54%
The estimate for compound 4 lay 2 percentage points below the measured number, within the range that was stated.
By their numbers in this assay, from the lowest: compound 2; then compound 1; then compound 4; then compound 3.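

The earlier compounds shown here showed nothing about the group on this aromatic carbon next to the ring nitrogen. In this assay, tert-butoxy in place of trifluoromethyl gives a number 22 percentage points lower from compound 3 to compound 4 (beyond the scatter), so the number does respond to what sits at this position, at least for this one change. Nothing available explains the drop.

On these data alone, whether an amine or an ethyl chain at this position would give a higher or lower number stays open. So does whether the same change would have a similar effect on the core of compound 1.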